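From a sulfur group to methylcarbamoyl

The source may report more compounds than this note shows. Statements on the series, on what has been measured and on what is new or still open speak of the compounds shown alone.

Measured in a functional assay (aorta) with Rattus norvegicus as the target; on this read-out lower numbers stand for an effect already at smaller amounts and higher numbers for an effect only at larger amounts of compound:
- Compound 1 `C/N=C(/S)C1=CC(C)(CF)Oc2ccc([N+](=O)[O-])cc21`: 1.62 nM
- Compound 2 `C/N=C(/S)C1=CC(CF)(CF)Oc2ccc([N+](=O)[O-])cc21`: 0.479 nM
- Compound 3 `C/N=C(/S)C1=CC(C)(C(F)(F)F)Oc2ccc([N+](=O)[O-])cc21`: 0.302 nM

Compound 1 has the highest number of the three, so it needs the largest amount for its effect. Compound 4 `CNC(=O)C1=CC(C)(CF)Oc2ccc([N+](=O)[O-])cc21` carries methylcarbamoyl on a double-bonded ring carbon, where compound 1 has a sulfur-bearing group: a group of 4 heavy atoms (2 carbon, 1 nitrogen, 1 oxygen; no ring) in place of a group of 4 heavy atoms (2 carbon, 1 nitrogen, 1 sulfur; no ring), on a double-bonded ring carbon. Going by the values given here, no measured step covers this exchange. Two steps change other places on the molecule: a 3.4-fold lower number from compound 1 to compound 2 (0.53 log units; beyond the scatter) and a 5.4-fold lower number from compound 1 to compound 3 (0.73 log units; beyond the scatter). Both are modest, and they offer only a rough guide to size. In this assay, among the compounds with values here, a step of similar or somewhat larger size is expected, towards a higher number, although no measured pair tests that direction. The expected step is a 6.2-fold higher number from compound 1 to compound 4 (0.79 log units; beyond the scatter). Compound 4 is estimated at 10 nM, with an expected range from 2 nM to 50 nM.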

Compound 4, half-maximal effective concentration: 8.91 nM
Beside the measured number, compound 4's estimate is 1.1-fold (0.05 log units) above it, within the range that was stated.
By their numbers in this assay, from the lowest: compounds 3 and 2 (each within the scatter of the next); then compound 1; then compound 4.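

The earlier compounds shown here varied only the fluorinated groups on the ring, so they said nothing about the sulfur-bearing group on the double-bonded ring carbon. In this assay this place proves sensitive: putting methylcarbamoyl there gives a 5.5-fold higher number from compound 1 to compound 4 (0.74 log units; beyond the scatter) even though the two groups have the same heavy-atom count and differ by one atom, oxygen for sulfur. Nothing available accounts for this shift.

On these data alone, whether the exchange has a similar effect on compound 2 or compound 3 remains open. So does how a carboxylic acid or an amine would fare on this carbon.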